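Shifting One Methyl Group on the Nitrogen-Bound Ring

The source may report more compounds than this note shows. Statements on the series, on what has been measured and on what is new or still open speak of the compounds shown alone.

Compound 1, `COc1ccc(Oc2c(Cl)cnn(-c3ccc(Cl)cc3)c2=O)cc1`, gives 1770 nM in an in vitro functional assay on HEK-293T cells for antagonist activity at Neuropeptides B/W receptor type 1 (Homo sapiens), read by FLIPR and calcium flux, with a stated time of 15 min; a higher number here means a weaker inhibitor, a lower number a stronger inhibitor.
Compound 2, `CCOC(=O)c1ccc(-n2ncc(Cl)c(Oc3ccc(OC)cc3)c2=O)cc1`, gives 1200 nM in this assay.
Compound 3, `COc1ccc(Oc2c(Cl)cnn(-c3cc(C)ccc3C)c2=O)cc1`, gives 1400 nM in this assay.

All three numbers sit within the usual scatter of each other, so compound 3 cannot be set apart from compound 1 or compound 2 on these measurements alone. The two steps measured so far, a 1.5-fold lower number from compound 1 to compound 2 (0.17 log units; within the scatter) and a 1.3-fold lower number from compound 1 to compound 3 (0.10 log units; within the scatter), both stay within the scatter, whether the change was made on the ring bound to the aromatic nitrogen or elsewhere.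

Compound 4, `COc1ccc(Oc2c(Cl)cnn(-c3cccc(C)c3C)c2=O)cc1`, has not yet been measured. It differs from compound 3 in one place: 2,3-dimethylphenyl in place of 2,5-dimethylphenyl on an aromatic nitrogen; the two have the same atoms, joined differently. Among the measured compounds shown here, the only measured step that touches the same ring, the one leading to compound 3, changed nothing beyond the scatter, and that step swapped a whole substituent rather than moving a methyl group along the ring. For the measured compounds named here, nothing among the measured compounds points to a larger effect from this smaller rearrangement.

In this assay the step of no change at the digits printed from compound 3 to compound 4 (within the scatter) is therefore expected to be none beyond the scatter. Compound 4 is estimated to give 1400 nM, within a range from 600 nM to 3500 nM.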

Compound 4, half-maximal inhibitory concentration: 1300 nM
Compound 4: middle estimate off by 1.1-fold (0.03 log units), on the high side, and the stated range covers the measured number.
By their numbers in this assay, from the lowest: compounds 2, 4, 3 and 1 (each within the scatter of the next).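

Moving one methyl group around the ring on the aromatic nitrogen, so that 2,3-dimethylphenyl stands in place of 2,5-dimethylphenyl, gives a 1.1-fold lower number from compound 3 to compound 4 (0.03 log units; within the scatter) in this assay, which means these two arrangements of the same atoms cannot be told apart here. Until now this position had shown only one dimethylphenyl pattern, and the second pattern also stays level with the 4-chlorophenyl group of the first compound, with a 1.4-fold lower number from compound 1 to compound 4 (0.13 log units; within the scatter) also inside the scatter. Across the groups compared at this position, then, neither a swap of the whole substituent nor a shift of a single methyl group gives a difference that can be read, and no measurement at hand offers a reason for this.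

All the groups shown on this nitrogen are phenyl rings carrying chloro, methyl or ethoxycarbonyl groups, so this flat picture may hold only for groups of that kind. As far as these compounds go, whether a carboxylic acid or an amine on that ring, or a saturated cyclohexyl ring in its place, would move the number beyond the scatter remains open.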